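Replacing pyridin-2-yl with 3-bromophenyl: expected cytotoxicity

The source may report more compounds than this note shows. Statements on the series, on what has been measured and on what is new or still open speak of the compounds shown alone.

Compound 1 `COc1ccc(-c2cnc(NC(=O)c3ccccn3)n2C)cc1` was examined in a toxicity assay on THP-1 cells (Homo sapiens) for inhibition; on this read-out higher numbers stand for lower toxicity in this test and lower numbers for higher toxicity in this test. In this assay compound 1 gives only a limit rather than a number, > 100000 nM. Compound 2 `COc1ccc(-c2ccnc(NC(=O)c3ccc(F)cc3)c2)cc1` likewise stops at a limit in this assay, > 100000 nM. Compound 3 `COc1ccc(-c2cnc(NC(=O)c3ccc(F)cc3)n2C(C)C)cc1` also returns a limit in this assay, > 50000 nM. Among the measured compounds shown here, two of the three values shown sit at the limit of > 100000 nM in this assay, at which 2 of the 3 values shown sit, and one at the limit of > 50000 nM in this assay, at which 1 of the 3 values shown sits, so compound 1 stands with the others at the least toxic end that this test can report, and no step between measured compounds can be sized.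

Compound 4 `COc1ccc(-c2cnc(NC(=O)c3cccc(Br)c3)n2C)cc1` has not yet been measured in this assay. It differs from compound 1 in one place: 3-bromophenyl in place of pyridin-2-yl on a carbonyl carbon. The measured compounds all stop at limits, and the step of a number no higher from compound 1 to compound 4 (the limit leaves the size open) is expected to be none beyond the scatter. Compound 4 is therefore estimated at 100000 nM, within 30000 nM to 300000 nM, and most likely reported once more as a limit.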

Compound 4, half-maximal cytotoxic concentration: > 100000 nM
Compound 4 ended at the assay's limit (the forecaster's own chance of this, stated with the estimate: 75%); the middle value sits exactly at the limit.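

No new step can be read in this assay: compound 1 and compound 4 both stop at limits, so the change from pyridin-2-yl to 3-bromophenyl cannot be sized. The compounds shown leave open at what concentration, if any, each would become toxic in this test.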